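Swapping a chain group on compound 3 for a tetrazole

A few compounds are considered here, and "the series" means these few. Any claim that something is new, unique, unknown or untested is made for them only; others in the source may bear on it.

In a functional assay (plasma) for inhibition, with Homo sapiens as the target (a higher number here means a weaker inhibitor, a lower number a stronger inhibitor), compound 1 (`C[C@@H](c1ccc(O)cc1)[C@H](O)/C=C/C1C2CCC(O2)C1C/C=C\CCCC(=O)O`) gives 240 nM while compound 2 (`C[C@@H](c1ccc(O)c(I)c1)[C@H](O)/C=C/C1C2CCC(O2)C1C/C=C\CCCC(=O)O`) gives 930 nM and compound 3 (`CC(CC/C=C\C[C@H]1C2CCC(O2)[C@H]1/C=C/[C@@H](O)[C@@H](C)c1ccccc1)C(=O)O`) gives 25000 nM as the highest number of the three. That makes compound 3 the weakest inhibitor measured so far.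

Compound 4 (`C[C@@H](c1ccccc1)[C@H](O)/C=C/[C@@H]1C2CCC(O2)[C@@H]1C/C=C\CCCc1nnn[nH]1`) has not been measured yet. It differs from compound 3 in one place: (1H-tetrazol-5-yl)methyl in place of 1-carboxyethyl on a saturated chain carbon, two bonds along the chain from a double-bonded chain carbon in a single change. Cut one bond further out, the same difference reads 2-carboxypropyl to 2-(1H-tetrazol-5-yl)ethyl.

Going by the values given here, the only measured step is a 3.9-fold higher number from compound 1 to compound 2 (0.59 log units; beyond the scatter) for iodo in place of hydrogen on an aromatic carbon. Among the compounds with values here, that step was modest and does not involve the groups exchanged here, so no measured step covers this swap directly. The values give only a rough guide: compound 1 at 240 nM and compound 2 at 930 nM both sit far below compound 3 at 25000 nM on this scale. A fall towards those two seems more likely than a further rise.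

The expected size of the change is a 17-fold lower number from compound 3 to compound 4 (1.22 log units; beyond the scatter) in this assay as a rough estimate with wide uncertainty. For compound 4 the estimated value is 1500 nM with an expected range from 250 nM to 10000 nM in this measurement.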

Compound 4, half-maximal inhibitory concentration: 3200 nM
For compound 4 the middle estimate is 2.1-fold (0.33 log units) below the measured one; low and high end bracket the measured number.
By their numbers in this assay, from the lowest: compound 1; then compound 2; then compound 4; then compound 3.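

In this assay, the swap on a saturated chain carbon, two bonds along the chain from a double-bonded chain carbon, gives a 7.8-fold lower number from compound 3 to compound 4 (0.89 log units; beyond the scatter), so this place affects inhibition as well as the aromatic carbon changed in the earlier pair. It also shows that this place can do without a carboxylic acid: compound 4 carries none, yet it is the stronger inhibitor of this pair. Nothing measured here explains why the number falls.

The swap changes two things at once, replacing the acid with a tetrazole ring and removing the methyl branch of 1-carboxyethyl, and a compound with 1-(1H-tetrazol-5-yl)ethyl at this place would help show how much of the step belongs to each part. The compounds shown also leave open how a primary amide or a hydroxamic acid would compare with the tetrazole here, and whether the tetrazole gives a similar result alongside the hydroxy-bearing aromatic ring of compound 1.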